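The source may hold more compounds than are shown below. What is called first, only, known or untested is meant among the compounds shown, and "the series" means these compounds.

Measured so far:
- compound 1, `ClCc1ccccc1Cn1cnc2ncnc(Cl)c21`, 13500 nM in a functional assay on NCI-H460 cells (Homo sapiens) for cytotoxicity, read by sulforhodamine B assay, with a stated time of 48 h; a higher number here means a weaker inhibitor of growth, a lower number a stronger inhibitor of growth
- compound 2, `ClCc1cccc(Cn2cnc3nc(Cl)nc(Cl)c32)c1`, 1690 nM in this assay

Compound 1 stands at the highest of the two numbers in this assay; compound 2 gives the lower number, and the gap between the two lies beyond the scatter. Going by the values given here, compound 2 differs from compound 1 in more than one place, so the two values show only that the pair sits apart, not which change carries it.

Compound 3, `ClCc1ccccc1Cn1cnc2nc(Cl)nc(Cl)c21`, is the next entry and is not yet measured in this assay. It differs from compound 1 by chloro in place of hydrogen on an aromatic carbon, on the aromatic carbon between two ring nitrogen atoms of the shared core, meta to a chloro group. Among the compounds with values here, no single step of this kind is available from measured compounds, so the size of the change in this assay is open. Compound 2 carries the same chloro on its core and gives 1690 nM, which gives some expectation that the step will go toward a lower number.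

The value of compound 3 in this assay is expected at 3500 nM, within 900 nM to 13000 nM, a step of a 3.9-fold lower number from compound 1 to compound 3 (0.59 log units; beyond the scatter) that is estimated, not measured.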

Compound 3, concentration for 50% growth inhibition: 2390 nM
Estimate against measurement, compound 3: 1.5-fold (0.17 log units) above; low and high end bracket the measured number.
By their numbers in this assay, from the lowest: compounds 2 and 3 (each within the scatter of the next); then compound 1.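

In this assay, going by these compounds alone, the aromatic carbon between two ring nitrogen atoms of the shared core proves sensitive to substitution: chloro in place of hydrogen there gives a 5.6-fold lower number from compound 1 to compound 3 (0.75 log units; beyond the scatter) and is the first change that can be read on its own. The gap between compound 1 and compound 2 could not be assigned to any single change, whereas this step ties a modest shift beyond the scatter to one atom at one position. Nothing at hand bears on the origin of the step, so the measurement fixes its size and direction only.

Going by these compounds, with a single step at this carbon, it remains open whether an amine, a methoxy group or a fluoro in place of the chloro would move the number in the same direction or by a similar amount. It is also open whether the step carries over to the substitution pattern of compound 2, since the compounds shown offer only one pair for reading this change.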